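The source may report more compounds than this note shows. Statements on the series, on what has been measured and on what is new or still open speak of the compounds shown alone.

Measured compounds:
Compound 1, `CN1Cc2c(Cl)cc(Cl)cc2[C@@H](c2cccc(NC(=O)[C@H](O)[C@@H](O)[C@H](O)[C@H](O)CO)c2)C1`: in an assay on cells (Kidney epithelial cell, kidney) for inhibition of sodium/hydrogen exchanger 3 (Homo sapiens), read by fluorescence, in the presence of a further agent that is not named here (on this read-out higher numbers stand for weaker inhibition and lower numbers for stronger inhibition), compound 1 gives 2510 nM.
Compound 2, `CN1Cc2c(Cl)cc(Cl)cc2C(c2cccc(S(=O)(=O)NCCOCCOCCOCCNC(=O)C(O)C(O)NCCOCCOCCOCCNS(=O)(=O)c3cccc(C4CN(C)Cc5c(Cl)cc(Cl)cc54)c3)c2)C1`: compound 2 gives 79.4 nM.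
Compound 3, `CN1Cc2c(Cl)cc(Cl)cc2C(c2cccc(S(=O)(=O)NCCOCCOCCNC(=O)C(O)C(O)NCCOCCOCCNS(=O)(=O)c3cccc(C4CN(C)Cc5c(Cl)cc(Cl)cc54)c3)c2)C1`: compound 3 gives 63.1 nM.

Among these three numbers, compound 2 holds the second highest value. Its nearest neighbour is compound 3, whose number is a little lower, but that gap lies within the usual scatter of repeated measurements, so the two cannot be told apart. The furthest is compound 1, whose number is far higher, a gap well beyond the scatter; compound 1 is also built quite differently, carrying a single core and a sugar-derived amide, while compound 2 and compound 3 each link two copies of the core through long chains.

Compound 4, `CN1Cc2c(Cl)cc(Cl)cc2[C@@H](c2cccc(S(=O)(=O)NCCOCCOCCOCCNC(O)C(O)C(=O)NCCOCCOCCOCCNS(=O)(=O)c3cccc([C@@H]4CN(C)Cc5c(Cl)cc(Cl)cc54)c3)c2)C1`, is the compound to be measured next. Compared with compound 2, the change is this: the two compounds have the same atoms and bonds; at least one stereo element is drawn with a configuration in one of them and without one in the other: 2 of 4 stereo elements differ; a stereocentre at a saturated ring carbon is drawn without a configuration in compound 2 and R in compound 4; a stereocentre at a saturated ring carbon is drawn without a configuration in compound 2 and S in compound 4. Nothing is added and nothing is taken away; only the handedness at two ring carbons is now fixed where before it was left open.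

For the measured compounds named here, no pair of measured compounds shows what such a fixing of configuration does here. With the atoms and bonds unchanged, the step from compound 2 to compound 4 is expected to stay within the scatter, a 1.1-fold lower number from compound 2 to compound 4 (0.05 log units; within the scatter). Compound 4 is therefore estimated at 70 nM, with a range from 25 nM to 200 nM.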

Compound 4, half-maximal inhibitory concentration: 200 nM
Compound 4: middle estimate off by 2.9-fold (0.46 log units), on the low side; measured number inside the range.
By their numbers in this assay, from the lowest: compounds 3 and 2 (each within the scatter of the next); then compound 4; then compound 1.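

In this assay, fixing the handedness at the two ring carbons gives a 2.5-fold higher number from compound 2 to compound 4 (0.40 log units; beyond the scatter), a modest shift but one that lies beyond the scatter. For the compounds shown here, this is the first sign that the configuration at these ring carbons can matter for inhibition even when no atom or bond changes, which compounds 1, 2 and 3 could not show, as no two of them differ in only one place. The step can point to only one recorded difference: the fact that one of compounds 2 and 4 is drawn with a defined configuration and the other without, at the place where they differ

Going by these compounds alone, compound 2 is drawn without a configuration at these carbons, so its drawing does not say which spatial forms it contains, and it remains open whether another combination of handedness at the two ring carbons would give a lower number than the one drawn for compound 4. From the compounds shown here alone, it is also open whether fixing the configuration would have a similar effect on a compound with a longer chain linking the two copies of the core, or with a carboxylic acid on that chain.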